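Working notes: bromo in place of hydroxymethyl

The compounds below may be only part of what the source reports. "The series", "measured", "known", "first", "only" and "open" are said of these compounds alone.

In an ADME assay on CHO-K1 cells (Cricetulus griseus) for cytotoxicity, read by MTT assay, with a stated time of 24 h (on this read-out higher numbers stand for lower toxicity in this test and lower numbers for higher toxicity in this test), compound 1 (`S=C(Nc1ccccc1)Nc1ccc2[nH]ccc2c1`) gives 337000 nM, compound 2 (`Oc1ccccc1NC(=S)Nc1ccc2[nH]ccc2c1`) gives 509000 nM and compound 3 (`OCc1ccc(NC(=S)Nc2ccc3[nH]ccc3c2)cc1`) gives 1080000 nM, the highest of the three numbers. Compound 4 (`S=C(Nc1ccc(Br)cc1)Nc1ccc2[nH]ccc2c1`) has bromo in place of hydroxymethyl on an aromatic carbon, para to a large group: bromo in place of hydroxymethyl on an aromatic carbon.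

The measured step closest to this change is a 3.2-fold higher number from compound 1 to compound 3 (0.51 log units; beyond the scatter), which introduces the hydroxymethyl that compound 4 lacks. The hydroxy step, a 1.5-fold higher number from compound 1 to compound 2 (0.18 log units; within the scatter), is a different group and bears on the change only loosely. Among the compounds with values here, no measured compound carries bromo, so the contribution of bromo itself is unknown. The working expectation is that most of the rise seen with compound 3 is lost, leaving compound 4 near compound 1 at 337000 nM. The expected step in this assay is a 3.9-fold lower number from compound 3 to compound 4 (0.59 log units; beyond the scatter), a modest move towards higher toxicity in this test. For compound 4 the estimated value is 280000 nM, with an expected range of 110000 nM to 650000 nM.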

Compound 4, concentration lethal to 50% of the cells: 220000 nM
For compound 4 the middle estimate is 1.3-fold (0.10 log units) above the measured one; low and high end bracket the measured number.
By their numbers in this assay, from the lowest: compounds 4, 1 and 2 (each within the scatter of the next, the first and the last beyond it); then compound 3.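

In this assay bromo in place of hydroxymethyl gives a 4.9-fold lower number from compound 3 to compound 4 (0.69 log units; beyond the scatter) and so does not keep the higher number seen with hydroxymethyl at this position on the aromatic ring. Set against hydrogen at the same place, bromo gives a 1.5-fold lower number from compound 1 to compound 4 (0.19 log units; within the scatter) and this step lies within the scatter, so among the three groups shown here only hydroxymethyl stands apart from hydrogen. Nothing measured on these compounds accounts for the difference between hydroxymethyl and bromo.

As far as these compounds go, it remains open whether the higher number is particular to hydroxymethyl or extends to other groups at this place, such as an aminomethyl or a carboxylic acid. Also open, from the compounds shown here alone, is whether bromo would stay level with hydrogen at other places on this ring.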